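A few compounds are considered here, and "the series" means these few. Any claim that something is new, unique, unknown or untested is made for them only; others in the source may bear on it.

Measured to date in this series:

- compound 1 `Cc1ccc(NC2=CC(=O)c3nc4n(c3C2=O)[C@H]2OC[C@@H](O)[C@H]2OC4)cc1`: 3480 nM
- compound 2 `CCCc1ccc(NC2=CC(=O)c3c(nc4n3[C@H]3OC[C@@H](O)[C@H]3OC4)C2=O)cc1`: > 4000 nM
- compound 3 `O=C1C(N2CCCCC2)=CC(=O)c2c1nc1n2[C@H]2OC[C@@H](O)[C@H]2OC1`: > 8000 nM

In a functional assay on ECa-109 cells for inhibition, with ECa-109 cell line (Homo sapiens) as the target, read by sulforhodamine B assay (a higher number here means a weaker inhibitor, a lower number a stronger inhibitor), compound 1 gives 3480 nM. Compound 2 is not resolved to a number; in this assay compound 2 reaches only the limit > 4000 nM. Compound 3 likewise gives only the limit > 8000 nM in this assay. So compound 2 stands at one of the two limits in the set, (the limit of > 4000 nM in this assay, at which 1 of the 3 values shown sits), with compound 3 sitting at the other, (the limit of > 8000 nM in this assay, at which 1 of the 3 values shown sits); only compound 1 carries a definite number, and nothing in the shown values allows a measured step to be sized.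

Compound 4 `CCOc1ccc(NC2=CC(=O)c3c(nc4n3[C@H]3OC[C@@H](O)[C@H]3OC4)C2=O)cc1` is not yet measured. It differs from compound 2 by ethoxy in place of propyl on an aromatic carbon. With compound 2 at a limit, no step size can be read from the measured pair. Compound 4 is expected to remain weak in this assay, near the region where compound 1 gives 3480 nM, and the step from compound 2 is estimated as a number no higher from compound 2 to compound 4 (the limit leaves the size open), which is not a change beyond the scatter. Compound 4 is therefore estimated at 4000 nM, within 1500 nM to 12000 nM.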

Compound 4, half-maximal inhibitory concentration: > 4000 nM
Compound 4 was reported as a limit; the forecaster's own chance of this, stated with the estimate: 50%; the middle value lies on the limit itself.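

In this assay compound 2 gives only the limit > 4000 nM. Among the compounds shown here, compound 4 likewise gives only a limit, > 4000 nM, so no step between compound 2 and compound 4 can be read. The compounds shown leave open whether ethoxy in place of propyl on an aromatic carbon changes the inhibition at all.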